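Replacing the 4-ethylphenyl Group of Compound 2

A few compounds are considered here, and "the series" means these few. Any claim that something is new, unique, unknown or untested is made for them only; others in the source may bear on it.

Compound 1 `CN1CCN(c2ccc(NC3=CC(=O)c4ncncc4C3=O)cc2)CC1`: 530 nM
Compound 2 `CCc1ccc(-c2ccc(NC3=CC(=O)c4ncncc4C3=O)cc2)cc1`: 1500 nM
Compound 3 `CC1=C(Nc2ccc(N3CCN(C)CC3)cc2)C(=O)c2cncnc2C1=O`: 3630 nM

These three values come from a functional assay on MIA PaCa-2 cells (Homo sapiens) for cytotoxicity, read by MTT assay, with a stated time of 72 h; on this read-out higher numbers stand for weaker inhibition and lower numbers for stronger inhibition. Compound 2, at 1500 nM, holds the middle place of the three. Compound 3 reads higher at 3630 nM, and compound 1 reads lower at 530 nM.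

The next compound, compound 4 `O=C1C(Nc2ccc(-c3cc(Cl)cc(Cl)c3)cc2)=CC(=O)c2ncncc21`, differs from compound 2 by one change: 3,5-dichlorophenyl in place of 4-ethylphenyl on an aromatic carbon. In words, 3,5-dichlorophenyl stands in place of 4-ethylphenyl on an aromatic carbon.

Within the data shown here, only one measured step falls at this place: a 2.8-fold higher number from compound 1 to compound 2 (0.45 log units; beyond the scatter), a modest one, which brought in the 4-ethylphenyl group in place of 4-methylpiperazin-1-yl. The other step, a 6.8-fold higher number from compound 1 to compound 3 (0.84 log units; beyond the scatter), is also modest, but it falls on a double-bonded ring carbon and bears only on the general size of steps in this small set. Among the measured compounds shown here, no measured compound carries the 3,5-dichlorophenyl group, so the data give no direction for this exchange. A modest step in this assay is the most that is expected, possibly none beyond the scatter, with neither direction favoured. The expected outcome is no change at the digits printed from compound 2 to compound 4 (within the scatter). For compound 4 the estimated value is 1500 nM, with an expected range from 500 nM to 4500 nM.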

Compound 4, half-maximal inhibitory concentration: 3100 nM
Compound 4: the middle estimate sits 2.1-fold (0.32 log units) below what was measured, within the range that was stated.
By their numbers in this assay, from the lowest: compound 1; then compound 2; then compounds 4 and 3 (each within the scatter of the next).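

In this assay, the exchange of 4-ethylphenyl for 3,5-dichlorophenyl gives a 2.1-fold higher number from compound 2 to compound 4 (0.32 log units; beyond the scatter) on this aromatic carbon. The read-out therefore responds to a change in the outer ring even though the two groups match in heavy atoms, aromatic rings, hydrogen-bond donors, hydrogen-bond acceptors and net charge; what differs is that two chlorine atoms enter and the ethyl carbons leave. Set against the 4-methylpiperazin-1-yl group of compound 1, the new group gives a 5.8-fold higher number from compound 1 to compound 4 (0.77 log units; beyond the scatter), and with a 2.8-fold higher number from compound 1 to compound 2 (0.45 log units; beyond the scatter) this means both aryl groups shown at this place read higher than 4-methylpiperazin-1-yl, with no compound shown going against that. No measurement is available that accounts for these steps.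

From the compounds shown here alone, it remains open how a morpholin-4-yl group, a 4-aminophenyl group or a benzoic acid at this place would read, and whether any of them would lie nearer compound 1 or compound 4. Also open is whether the two chlorine atoms act together, since a single chlorine on the outer ring, or a methyl on the double-bonded ring carbon alongside 3,5-dichlorophenyl, is not among the compounds shown here.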